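The source may report more compounds than this note shows. Statements on the series, on what has been measured and on what is new or still open speak of the compounds shown alone.

Measured in a functional assay on MGC-803 cells (Homo sapiens) for inhibition, read by CCK-8 assay, with a stated time of 48 h; on this read-out lower numbers stand for stronger inhibition and higher numbers for weaker inhibition:
- compound 1 `COc1ccc(CN(C(=O)CSC(=S)N2CCN(C(=O)OC(C)(C)C)CC2)c2cc(OC)c(OC)c(OC)c2)cc1`: 310 nM
- compound 2 `COc1ccc(CN(C(=O)CSC(=S)N2CCN(Cc3ccc(C(C)(C)C)cc3)CC2)c2cc(OC)c(OC)c(OC)c2)cc1`: 5390 nM
- compound 3 `COc1ccc(CN(C(=O)CSC(=S)N2CCOCC2)c2cc(OC)c(OC)c(OC)c2)cc1`: 2370 nM

Compound 3 holds the middle place among these three numbers, with only compound 2 higher. Compound 4 `COc1ccc(CN(C(=O)CSC(=S)N2CCCc3cc(C)ccc32)c2cc(OC)c(OC)c(OC)c2)cc1` differs from it at one place, with 6-methyl-1,2,3,4-tetrahydroquinolin-1-yl in place of morpholin-4-yl on a thiocarbonyl carbon. Going by the values given here, the only measured step that bears on this, a 17-fold higher number from compound 1 to compound 2 (1.24 log units; beyond the scatter), is large, but it concerns a different exchange, on an amine nitrogen in a ring. It shows that the number can move far, yet gives no direction here. Among the compounds with values here, no measured compound carries the entering group. In this assay, therefore, a slight drift towards a lower number is expected, probably none beyond the scatter. The estimated step is a 1.6-fold lower number from compound 3 to compound 4 (0.20 log units; within the scatter). For compound 4 the estimated value is 1500 nM, with an expected range of 400 nM to 5500 nM.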

Compound 4, half-maximal inhibitory concentration: 6490 nM
Estimate against measurement, compound 4: 4.3-fold (0.64 log units) below, outside the stated range (above it).
By their numbers in this assay, from the lowest: compound 1; then compound 3; then compounds 2 and 4 (each within the scatter of the next).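

Going by these compounds alone, at the thiocarbonyl carbon, in this assay, replacing morpholin-4-yl with 6-methyl-1,2,3,4-tetrahydroquinolin-1-yl gives a 2.7-fold higher number from compound 3 to compound 4 (0.44 log units; beyond the scatter) and provides the first measured step at this place. The number therefore responds to the group held there, and this larger group, with its aromatic ring of carbon only, does not lower it. No available measurement explains the step. From the compounds shown here alone, it remains open whether the methyl group contributes to this step, and how a plain piperidine or the unsubstituted 1,2,3,4-tetrahydroquinolin-1-yl group would read at the same place.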